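Moving the hydroxy group around the phenyl ring

This account rests on a few compounds, and the source may have more. Where it says the series, first, only, none or still open, it means among the compounds named here.

Compound 1, `O=C(/C=C\c1ccccc1)N1N=C(c2ccncc2)OC1c1c[nH]c2ccccc12`: in an ADME assay on PANC-1 cells (Homo sapiens) for cytotoxicity, read by MTT assay, with a stated time of 48 h (a lower number here means a stronger inhibitor of growth, a higher number a weaker inhibitor of growth), compound 1 gives > 30 ug/mL, which is a limit of the assay and not a number.
Compound 2, `O=C(/C=C\c1ccccc1O)N1N=C(c2ccncc2)OC1c1c[nH]c2ccccc12`: in this assay compound 2 gives > 30 ug/mL, again a limit.
Compound 3, `O=C(/C=C\c1cccc(O)c1)N1N=C(c2ccncc2)OC1c1c[nH]c2ccccc12`: in this assay compound 3 gives > 30 ug/mL, also a limit.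

Compound 3 thus stands only at a limit, and the two other values shown sit at that same limit, so no ordering among the three can be read. The steps a step that the two limits leave unreadable from compound 1 to compound 2, a step that the two limits leave unreadable from compound 1 to compound 3 and a step that the two limits leave unreadable from compound 2 to compound 3 are unreadable because the limit of > 30 ug/mL in this assay, at which 3 of the 3 values shown sit, hides any difference between their endpoints.

Compound 4, `O=C(/C=C\c1ccc(O)cc1)N1N=C(c2ccncc2)OC1c1c[nH]c2ccccc12`, differs from compound 3 by 4-hydroxyphenyl in place of 3-hydroxyphenyl on a double-bonded chain carbon bound to a double-bonded chain carbon. Among the measured compounds shown here, the only measured step that moves the hydroxy group around the ring gave no readable size, so in this assay no direction can be expected beyond the scatter, and the most likely outcome is that compound 4 again reaches only the limit. Compound 4 is therefore expected to give about 40 ug/mL, within 15 ug/mL to 100 ug/mL, which is an estimated step that the limit leaves unreadable from compound 3 to compound 4.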

Compound 4, concentration for 50% growth inhibition: > 30 ug/mL
Compound 4: no number, only a limit (the forecaster's own chance of this, stated with the estimate: 80%); the middle value does not contradict the limit.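

No new step can be read between compound 4 and compound 1, compound 2 or compound 3, because all four stop at the same limit, which is not a number: the limit of > 30 ug/mL in this assay, at which 4 of the 4 values shown sit. The compounds shown leave open whether having the hydroxy group, or moving it around the phenyl ring, makes any difference in this assay at all.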